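Three Limits and an Oxazole Swap

This account rests on a few compounds, and the source may have more. Where it says the series, first, only, none or still open, it means among the compounds named here.

Compound 1 `COC(=O)/C=C/CNc1ccc(Cl)c(S(=O)(=O)N(C)C)c1` reads > 30000 nM as a limit.
Compound 2 `C=CC(=O)Nc1scc(-c2ccccc2)c1C(=O)OCC` reads > 30000 nM as a limit.
Compound 3 `C=CC(=O)N(CC(=O)OCC)c1nc(-c2ccccc2)cs1` reads > 30000 nM as a limit.

Compound 3 has no number of its own in a functional assay on HCT-116 cells (Homo sapiens) for antiproliferative activity, read by MTT assay, with a stated time of 72 h (on this read-out lower numbers stand for stronger inhibition and higher numbers for weaker inhibition), and sits with the other two at the limit of > 30000 nM in this assay, at which 3 of the 3 values shown sit. Compound 4 `C=CC(=O)N(Cc1cc(C)no1)c1nc(-c2ccccc2)cs1` carries 3-methyl-1,2-oxazol-5-yl in place of ethoxycarbonyl on a saturated chain carbon bound to an amide-type nitrogen. Among the compounds with values here, no measured pair shows what such a change does, so in this assay only a modest step toward stronger inhibition is expected, possibly none beyond the scatter. The estimated step is an at least 1.5-fold lower number from compound 3 to compound 4 (0.17 log units; that floor lies within the scatter). For compound 4 the estimated half-maximal inhibitory concentration is 20000 nM within an expected range of 5000 nM to 60000 nM.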

Compound 4, half-maximal inhibitory concentration: > 30000 nM
Compound 4: a limit, no number (the forecaster's own chance of this, stated with the estimate: 60%); at least 1.5-fold (0.17 log units) between middle value and limit.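

Compound 3 and compound 4 both stand as limits and not as numbers, so no step can be read between them. The compounds shown leave open which structural change, if any, would give a readable number: the limit of > 30000 nM in this assay, at which 4 of the 4 values shown sit.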